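Methoxyphenyl to Nitrophenyl: What to Expect of Compound 3

A few compounds are considered here, and "the series" means these few. Any claim that something is new, unique, unknown or untested is made for them only; others in the source may bear on it.

Compound 1 `COc1ccccc1C(C1=C(O)C(=O)c2ccccc2C1=O)c1c[nH]c2ccccc12` was tested in a functional assay on HeLa cells (Homo sapiens) for cytotoxicity, read by MTT assay, with a stated time of 48 h (a lower number here means a stronger inhibitor, a higher number a weaker inhibitor), and gave 128000 nM, the higher of the two numbers recorded so far. Compound 2 `O=C1C(O)=C(C(c2ccccc2)c2c(-c3ccccc3)[nH]c3ccccc23)C(=O)c2ccccc21` gave 18800 nM in this assay, a lower number separated from compound 1 by a gap beyond the usual scatter. The unmeasured compound 3 `O=C1C(O)=C(C(c2ccc([N+](=O)[O-])cc2)c2c[nH]c3ccccc23)C(=O)c2ccccc21` differs from compound 1 at one place: 4-nitrophenyl in place of 2-methoxyphenyl on a saturated chain carbon bound to an aromatic carbon and a double-bonded ring carbon. Within the data shown here, no pair of measured compounds isolates this exchange, so the expectation rests on little. Compound 3 is expected to give 60000 nM in this assay, within a range from 15000 nM to 250000 nM. The expected step is a 2.1-fold lower number from compound 1 to compound 3 (0.33 log units; beyond the scatter), toward a lower number, of modest size at most.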

Compound 3, half-maximal inhibitory concentration: 14800 nM
Estimate against measurement, compound 3: 4.1-fold (0.61 log units) above; the measured number lies below the stated range.
By their numbers in this assay, from the lowest: compounds 3 and 2 (each within the scatter of the next); then compound 1.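

In this assay, 4-nitrophenyl in place of 2-methoxyphenyl on this saturated chain carbon gives an 8.6-fold lower number from compound 1 to compound 3 (0.94 log units; beyond the scatter). This is the first single exchange shown at this place, and it shows that the number responds to the aryl group carried there. No evidence is available that bears on this step. Going by these compounds, whether the lower number comes from the arrival of 4-nitrophenyl or the departure of 2-methoxyphenyl remains open. Also open, on these data alone, is how a phenyl ring carrying an amine or a carboxylic acid would behave at this place in this assay.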